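The source may hold more compounds than are shown below. What is called first, only, known or untested is meant among the compounds shown, and "the series" means these compounds.

Compound 1 `COC(=O)/C=C/c1ccc2c(c1)C=C([N+](=O)[O-])C(C(F)(F)F)O2` is the strongest inhibitor among the three compounds measured in an assay on 1321N1 cells for antagonist activity at P2Y purinoceptor 6 (Homo sapiens), read by FLIPR and calcium flux (on this read-out higher numbers stand for weaker inhibition and lower numbers for stronger inhibition), where compound 1 gives 2570 nM. Its nearest neighbour on this read-out is compound 3 `O=[N+]([O-])C1=Cc2cc(C#Cc3ccc(Cl)cc3)ccc2OC1C(F)(F)F`, which gives 5350 nM in this assay, a step beyond the scatter. Furthest away stands compound 2 `CC1Oc2ccc(I)cc2C=C1[N+](=O)[O-]`, which carries only a single iodo on its aromatic ring and gives 36800 nM in this assay, a gap also beyond the scatter.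

Compound 4 `O=[N+]([O-])C1=Cc2cc(Cl)ccc2OC1C(F)(F)F` has not yet been measured. It differs from compound 1 by chloro in place of 2-(methoxycarbonyl)ethenyl on an aromatic carbon. For the measured compounds named here, no pair of measured compounds shows this change directly, so its size can only be expected, not read off. Compound 2, with its lone halogen on the ring and its value of 36800 nM, points toward weaker inhibition for compound 4. The expected step from compound 1 to compound 4 is therefore one toward weaker inhibition, beyond the scatter, of a 5.8-fold higher number from compound 1 to compound 4 (0.77 log units; beyond the scatter). Compound 4 is estimated at 15000 nM, with a range from 4000 nM to 60000 nM.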

Compound 4, half-maximal inhibitory concentration: 1790 nM
Beside the measured number, compound 4's estimate is 8.4-fold (0.92 log units) above it; the measured number lies below the stated range.
By their numbers in this assay, from the lowest: compounds 4 and 1 (each within the scatter of the next); then compound 3; then compound 2.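

Replacing 2-(methoxycarbonyl)ethenyl with chloro on this aromatic carbon gives a 1.4-fold lower number from compound 1 to compound 4 (0.16 log units; within the scatter) in this assay, so the two groups cannot be told apart on this read-out. Across this one pair, the number does not follow the count of heavy atoms or of hydrogen-bond acceptors in the group at this position, even though the entering chloro has far fewer of both than the group it replaces. Nothing measured here accounts for this match.

On these data alone, whether an amine, a carboxylic acid or a longer chain on the same aromatic carbon would also stay within the scatter of these two compounds remains open. The role of the trifluoromethyl group on the shared core is also open: no pair shown differs at that group alone.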